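The source may report more compounds than this note shows. Statements on the series, on what has been measured and on what is new or still open speak of the compounds shown alone.

Compound 1, `CCN(Cc1ccoc1)C(=O)COc1ccc(C)cc1`, gives 136 nM in an assay on HEK293 cells for agonist activity at transient receptor potential cation channel subfamily M member 8 (Homo sapiens), read by fluorescence and calcium flux, with a stated time of 15 min; a lower number here means that less compound is needed, a higher number that more compound is needed for the effect.
Compound 2, `CCN(Cc1cccs1)C(=O)COc1ccc(F)cc1`, gives 422 nM in this assay.
Compound 3, `Cc1ccc(OCC(=O)N(CCCO)Cc2cccs2)cc1`, gives 3000 nM in this assay.

Of these three, compound 3 stands at the highest number, so that more of it is needed for the effect than of either of the others; its gap to compound 2 and its larger gap to compound 1 both lie beyond the usual scatter of the measurement. Compound 4, `Cc1ccc(OCC(=O)N(Cc2cccs2)c2ccon2)cc1`, has not been measured. It differs from compound 3 in one place: 1,2-oxazol-3-yl in place of 3-hydroxypropyl on an amide-type nitrogen. Among the measured compounds shown here, no pair of measured compounds shows the effect of this particular exchange, so the size of the step can only be guessed from how far compound 3 sits from the other two. Compound 4 is expected to need less compound than compound 3, with an estimated step of moderate size in this assay of a 3.3-fold lower number from compound 3 to compound 4 (0.52 log units; beyond the scatter). Compound 4 is therefore estimated at 900 nM in this assay, within a range from 250 nM to 3500 nM.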

Compound 4, half-maximal effective concentration: 2 nM
For compound 4 the middle estimate is 450-fold (2.65 log units) above the measured one; the measured number lies below the stated range.
By their numbers in this assay, from the lowest: compound 4; then compound 1; then compound 2; then compound 3.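

Among the compounds shown here, the exchange of 3-hydroxypropyl for 1,2-oxazol-3-yl on the amide-type nitrogen gives a 1500-fold lower number from compound 3 to compound 4 (3.18 log units; beyond the scatter) in this assay and so shows that this position can carry a very large step, which the earlier compounds, with no pair differing in one place, could not show. The change swaps an open chain with a hydrogen-bond donor for a five-membered aromatic ring with none, and the number falls far beyond the scatter. Nothing measured here bears on why the step is so large.

The compounds shown leave open whether the step follows from the ring entering or from the hydroxyl leaving, a distinction that a plain propyl chain or a phenyl ring on the same nitrogen would address. On these data alone, it also remains open whether the step would keep its size with a fluorine in place of the methyl on the other ring.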